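This account rests on a few compounds, and the source may have more. Where it says the series, first, only, none or still open, it means among the compounds named here.

Of the compounds shown here, three on one shared core have numbers so far in a functional assay on MDA-MB-231 cells (Homo sapiens) for antiproliferative activity, read by sulforhodamine B assay, with a stated time of 48 h (a lower number here means a stronger inhibitor of growth, a higher number a weaker inhibitor of growth), on record. Compound 1 (`Cc1ccc(-c2cn(CCCN3C(=O)COc4ccccc43)nn2)cc1`) stands at 1120 nM and compound 2 (`CCCCCCc1cn(CCCN2C(=O)COc3ccccc32)nn1`) at 1100 nM while compound 3 (`O=C1COc2ccccc2N1CCCn1cc(-c2cccnc2)nn1`) stands at 3000 nM as the highest of the three and thus the weakest inhibitor of growth among them. Compound 4 (`O=C1COc2ccccc2N1CCCn1cc(CO)nn1`) has not yet been measured. It carries hydroxymethyl in place of pyridin-3-yl on an aromatic carbon of the five-membered aromatic ring with 3 nitrogen (hydroxymethyl in place of pyridin-3-yl on an aromatic carbon). Going by the values given here, three measured steps bear on that carbon. Hexyl in place of 4-methylphenyl gives (a 1.0-fold lower number from compound 1 to compound 2 (0.01 log units; within the scatter)) so these two groups are not told apart. Pyridin-3-yl in place of 4-methylphenyl gives (a 2.7-fold higher number from compound 1 to compound 3 (0.43 log units; beyond the scatter)) and pyridin-3-yl in place of hexyl gives (a 2.7-fold higher number from compound 2 to compound 3 (0.44 log units; beyond the scatter)). Neither of these is large, and no measured group is as small as hydroxymethyl or carries its hydrogen-bond donor, so the data offer no direct comparison. Starting from compound 3 (3000 nM) a modest move to a higher number is expected in this assay for this change, though a result within the scatter would not surprise. The estimated step is (a 1.3-fold higher number from compound 3 to compound 4 (0.12 log units; within the scatter)). Compound 4 is estimated at (4000 nM) within an expected range (1500 nM to 12000 nM).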

Compound 4, concentration for 50% growth inhibition: 5700 nM
Beside the measured number, compound 4's estimate is 1.4-fold (0.15 log units) below it; the measured number falls inside the stated range.
By their numbers in this assay, from the lowest: compounds 2 and 1 (each within the scatter of the next); then compounds 3 and 4 (each within the scatter of the next).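

In this assay, hydroxymethyl on this aromatic carbon is not told apart from pyridin-3-yl (a 1.9-fold higher number from compound 3 to compound 4 (0.28 log units; within the scatter)), while it stands clearly apart from both hexyl (a 5.2-fold higher number from compound 2 to compound 4 (0.71 log units; beyond the scatter)) and 4-methylphenyl (a 5.1-fold higher number from compound 1 to compound 4 (0.71 log units; beyond the scatter)). The four groups now form two pairs, with compounds 1 and 2 at the lower numbers and compounds 3 and 4 at the higher ones, and the presence of a ring does not sort them: compounds 1 and 3 carry a six-membered aromatic ring yet fall in different pairs, and compounds 2 and 4 carry none yet also fall in different pairs. No measurement is at hand that would explain this split.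

The compounds shown leave open whether the hydroxy group itself or the short chain goes with the higher number of compound 4, which a plain methyl, a methoxymethyl or a longer chain ending in hydroxy could separate. They also leave open how an amine or a carboxylic acid on this carbon would compare.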